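The source may report more compounds than this note shows. Statements on the series, on what has been measured and on what is new or still open speak of the compounds shown alone.

Three compounds of the series have been run in a physicochemical assay for lipophilicity, read by HPLC, using the shake flask method, measured as octanol-water partition, at pH 7.4; on this read-out higher numbers stand for higher lipophilicity and lower numbers for lower lipophilicity. Compound 1 `Cc1cc2ncccc2cc1Nc1ncc2c(n1)n(C1CCOCC1)c(=O)n2C` gives 2.5. Compound 2 `Cc1cc2nnccc2cc1Nc1ncc2c(n1)n(C1CCOCC1)c(=O)n2C` gives 2.2, which lies within the scatter of compound 1. Compound 3 `Cc1cc2ncccc2cc1Nc1ncc2c(n1)n(C1CCN(C)CC1)c(=O)n2C` gives 1.8. How the core of compound 2 differs from the core of compound 1 is not broken down here. Compound 3 is compound 1 with a single change: 1-methylpiperidin-4-yl in place of oxan-4-yl on an aromatic nitrogen That change produced a number 0.70 log units lower from compound 1 to compound 3 (beyond the scatter), beyond the scatter.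

Compound 4 `Cc1cc2nnccc2cc1Nc1ncc2c(n1)n(C1CCN(C)CC1)c(=O)n2C` has not yet been measured in this assay. It relates to compound 2 exactly as compound 3 relates to compound 1: 1-methylpiperidin-4-yl in place of oxan-4-yl on an aromatic nitrogen The change occurs twice across the four compounds, and the surroundings of the place are the same word for word in both cases, so the change is the same, not merely the same kind. Among the compounds with values here, only one measured instance of it exists, so the expectation rests on that single step. The expected step is a number 0.70 log units lower from compound 2 to compound 4 (beyond the scatter), set alongside a number 0.70 log units lower from compound 1 to compound 3 (beyond the scatter), on the assumption that the change carries over unchanged to the second core. Compound 4 is thus estimated at 1.5, with a range from 1.1 to 1.9.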

Compound 4, distribution coefficient: 1.2
Beside the measured number, compound 4's estimate is 0.30 log units above it, and the stated range covers the measured number.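

Across the two cores, 1-methylpiperidin-4-yl in place of oxan-4-yl on an aromatic nitrogen gives two steps in this assay (a number 0.70 log units lower from compound 1 to compound 3 (beyond the scatter)) and (a number 1.00 log units lower from compound 2 to compound 4 (beyond the scatter)), which run the same way and each lie beyond the scatter. The direction of the change therefore carries over between these two cores, but two single pairs do not fix one size for the step and say nothing about any further core. No measurement at hand accounts for the size of either step.

The compounds shown leave open how the read-out would run with another group at this place, such as piperidin-4-yl without its methyl group or a cyclohexyl ring bearing a carboxylic acid. They also leave open what a longer chain, such as propyl, would do in place of the methyl group on the piperidine nitrogen, on either core.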